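This account rests on a few compounds, and the source may have more. Where it says the series, first, only, none or still open, it means among the compounds named here.

Compound 1 `COc1ccc(CN(C(=O)Cn2cc(COc3cc(=O)oc4ccccc34)nn2)c2cc(OC)c(OC)c(OC)c2)cc1`: 3660 nM
Compound 2 `COc1ccc(CN(C(=O)Cn2cc(CSc3nncs3)nn2)c2cc(OC)c(OC)c(OC)c2)cc1`: 5000 nM

Both numbers come from a functional assay on MGC-803 cells (Homo sapiens) for antiproliferative activity, read by MTT assay, with a stated time of 48 h; a higher number here means a weaker inhibitor, a lower number a stronger inhibitor. Compound 2, at 5000 nM, lies within the usual scatter of compound 1, at 3660 nM, so the two cannot be told apart in this test.

The next compound, compound 3 `COc1ccc(CN(C(=O)Cn2cc(CNS(=O)(=O)c3ccc(C)cc3)nn2)c2cc(OC)c(OC)c(OC)c2)cc1`, keeps the shared core and alters one group: ((4-methylphenyl)sulfonyl)amino in place of (1,3,4-thiadiazol-2-yl)sulfanyl on a saturated chain carbon bound to an aromatic carbon. In words, ((4-methylphenyl)sulfonyl)amino stands in place of (1,3,4-thiadiazol-2-yl)sulfanyl, on a saturated chain carbon bound to an aromatic carbon.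

Within the data shown here, only one measured step bears on this change, since it also exchanges the group at that same place. That step is a 1.4-fold higher number from compound 1 to compound 2 (0.14 log units; within the scatter), so two quite different groups there gave values within the scatter. Among the measured compounds shown here, no measured compound carries the new group, and one step is thin evidence, so the range must stay wide. Nothing in these data points to a real shift in either direction.

The expected step is small: a 1.1-fold lower number from compound 2 to compound 3 (0.05 log units; within the scatter), an estimate that stays within the scatter. For compound 3 the estimated value is 4500 nM, with an expected range of 1700 nM to 12000 nM.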

Compound 3, half-maximal inhibitory concentration: 1580 nM
Estimate against measurement, compound 3: 2.8-fold (0.45 log units) above; the whole stated range lies above it.
By their numbers in this assay, from the lowest: compound 3; then compounds 1 and 2 (each within the scatter of the next).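

In this assay, the place on a saturated chain carbon bound to an aromatic carbon now proves able to shift the number: ((4-methylphenyl)sulfonyl)amino in place of (1,3,4-thiadiazol-2-yl)sulfanyl gives a 3.2-fold lower number from compound 2 to compound 3 (0.50 log units; beyond the scatter) and so goes beyond the scatter, which the earlier pair of groups did not do. Among these compounds, the same group also separates from the larger group of 12 heavy atoms, with a 2.3-fold lower number from compound 1 to compound 3 (0.36 log units; beyond the scatter) on that exchange, so compound 3 is the one compound of the three whose steps to both others lie beyond the scatter, though both steps are modest. No measurement of any property of these groups is available to explain this result.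

The three compounds cannot show which part of ((4-methylphenyl)sulfonyl)amino matters, whether the methyl on the ring, the ring itself, or the sulfonyl with its amino hydrogen. From the compounds shown here alone, it also stays open what a plain amine, a carboxylic acid or a phenylsulfonylamino group without the methyl would give at this place.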